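Cytotoxicity series at one concentration: methoxy to hydroxy

This account rests on a few compounds, and the source may have more. Where it says the series, first, only, none or still open, it means among the compounds named here.

Measured compounds:
compound 1 `Cc1cc(O)cc(-c2nn(CC#N)cc2-c2ccnc(-c3ccc(Oc4ccccc4)cc3)c2)c1` with -4%
compound 2 `COc1cc(C)cc(-c2nn(CC#N)cc2-c2ccnc(-c3ccc(N(C)C)cc3)c2)c1` with 2%

In a functional assay on ACHN cells (Homo sapiens) for cytotoxicity, read by sulforhodamine B assay, with a stated time of 48 h, tested at 1 uM (a lower number here means a stronger effect, a higher number a weaker effect of the compound at the concentration tested), compound 1 gives -4%. In this assay compound 2 gives 2%. Compound 2 sits at one end of the two numbers shown, but its distance to compound 1 lies within the scatter, so the two cannot be told apart; both read as no effect at the concentration tested. Going by the values given here, the two structures differ in two places, so no single step between them can be drawn from the data.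

Compound 3 `Cc1cc(O)cc(-c2nn(CC#N)cc2-c2ccnc(-c3ccc(N(C)C)cc3)c2)c1` has not been measured. It differs from compound 2 by hydrogen in place of methyl on an oxygen on an aromatic ring. Compound 1 already carries the hydroxy group, and its number in this assay is -4%, so nothing in the data points to a change of effect from this exchange. The step from compound 2 to compound 3 is expected to be a number 2 percentage points lower from compound 2 to compound 3 (within the scatter), that is, none beyond the scatter. Compound 3 is therefore estimated at 0%, in the range -12% to 12%.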

Compound 3, a percentage reported as activity, at one concentration (the size of the read-out at that concentration, not a potency): 18%
The estimate for compound 3 lay 18 percentage points below the measured number; the whole stated range lies below it.
By their numbers in this assay, from the lowest: compounds 1 and 2 (each within the scatter of the next); then compound 3.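

In this assay, hydrogen in place of methyl on the oxygen is not a neutral exchange in the dimethylamino series: methoxy to hydroxy gives a number 16 percentage points higher from compound 2 to compound 3 (beyond the scatter), which means a weaker effect at the concentration tested. The hydroxy group alone does not set the reading, since with hydroxy held constant, dimethylamino in place of phenoxy on an aromatic carbon gives a number 22 percentage points higher from compound 1 to compound 3 (beyond the scatter), again towards a weaker effect, so the result of the 3-hydroxy-5-methylphenyl group depends on the substituent carried at that second place in these compounds. The data shown offer nothing that accounts for either step.

On these data alone, it remains open whether methoxy to hydroxy would shift the reading in the same way with phenoxy in place of dimethylamino, so the two steps cannot yet be combined into a single trend. It is also open whether an ethoxy group or an amino group in place of the hydroxy group would read closer to compound 2 or to compound 3, and a single concentration gives no potency for any of these compounds.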